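Replacing cyclohexyloxy with pentyl on the shared core

The source may hold more compounds than are shown below. What is called first, only, known or untested is meant among the compounds shown, and "the series" means these compounds.

Of the compounds shown here, three have been measured in an assay on CHO cells for antagonist activity at transient receptor potential cation channel subfamily V member 1 (Homo sapiens), read by FLIPR; a lower number here means a stronger inhibitor, a higher number a weaker inhibitor. Going by the values given here, compound 3 `CC(C(=O)NCc1ccc(C(F)(F)F)cc1OC1CCCCC1)c1ccc(NS(C)(=O)=O)c(F)c1` gives 0.7 nM, level with compound 2 `Cc1ccc(N2CCN(c3cc(C(F)(F)F)ccc3CNC(=O)C(C)c3ccc(NS(C)(=O)=O)c(F)c3)CC2)cc1` at 0.7 nM, and together these are the lowest numbers so far; compound 1 `CCCCN(C)c1cc(C(F)(F)F)ccc1CNC(=O)C(C)c1ccc(NS(C)(=O)=O)c(F)c1` gives 1.2 nM. Among the compounds with values here, the only single-point step measured, a 1.7-fold lower number from compound 1 to compound 3 (0.23 log units; within the scatter), sits within the scatter. Compound 4 `CCCCCc1cc(C(F)(F)F)ccc1CNC(=O)C(C)c1ccc(NS(C)(=O)=O)c(F)c1` is the next variation: pentyl in place of cyclohexyloxy on an aromatic carbon. Within the data shown here, no measured step exchanges cyclohexyloxy for pentyl, but the one comparison that alters this aromatic carbon moved little, and compound 2 carries yet another group there at a comparable number. The step expected is a 1.4-fold higher number from compound 3 to compound 4 (0.15 log units; within the scatter), nothing beyond the scatter. Compound 4 is estimated at 1 nM, within a range from 0.4 nM to 2.5 nM.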

Compound 4, inhibition constant: 0.4 nM
Beside the measured number, compound 4's estimate is 2.5-fold (0.40 log units) above it; low and high end bracket the measured number.
By their numbers in this assay, from the lowest: compounds 4, 2, 3 and 1 (each within the scatter of the next, the first and the last beyond it).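

In this assay this aromatic carbon accepts a pentyl chain, with no ring and no hydrogen-bond acceptor, in place of cyclohexyloxy without a change that stands clear of the scatter (a 1.8-fold lower number from compound 3 to compound 4 (0.24 log units; within the scatter)). Going by these compounds alone, the exchange of butyl(methyl)amino for pentyl gives the first step at this position that is beyond the scatter, though a modest one (a 3.0-fold lower number from compound 1 to compound 4 (0.48 log units; beyond the scatter)). No measurement shown here bears on why these groups differ.

Going by these compounds, whether a longer chain such as heptyl or a shorter one such as propyl would hold this level remains open. On these data alone, a carboxylic acid on this carbon also remains open.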